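From cyclooctyl to cyclohexyl on an amine nitrogen

A few compounds are considered here, and "the series" means these few. Any claim that something is new, unique, unknown or untested is made for them only; others in the source may bear on it.

Compound 1 `C=C[C@]1(C)CC[C@@H](C(=C)Cn2ccnc2)C[C@H]1C(=C)C` gives 15700 nM
Compound 2 `C=C[C@]1(C)CC[C@@H](C(=C)CNC2CCCCCCC2)C[C@H]1C(=C)C` gives 5900 nM

In a functional assay on HeLa cells (Homo sapiens) for antiproliferative activity, read by WST assay, with a stated time of 24 h (on this read-out higher numbers stand for weaker inhibition and lower numbers for stronger inhibition), compound 2 gives 5900 nM and compound 1 gives 15700 nM as the other number. Compound 2 therefore holds the lower of the two values and shows the stronger inhibition, and the gap between them lies beyond the usual scatter of repeated measurements.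

The next compound is compound 3 `C=C[C@]1(C)CC[C@@H](C(=C)CNC2CCCCC2)C[C@H]1C(=C)C` with cyclohexyl in place of cyclooctyl on an amine nitrogen and the rest of compound 2 unchanged. Among the measured compounds shown here, no measured pair of compounds shows what a swap like this does on its own, so any forecast here is uncertain. The starting point is compound 2 at 5900 nM and a modest move towards a higher number in this assay is expected, one that may not clear the scatter. The estimated change is a 1.4-fold higher number from compound 2 to compound 3 (0.13 log units; within the scatter) and it counts as a small step. For compound 3 the expected value is 8000 nM with an estimated range from 3500 nM to 18000 nM as the likely span.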

Compound 3, half-maximal inhibitory concentration: 3390 nM
For compound 3 the middle estimate is 2.4-fold (0.37 log units) above the measured one; measured number below the stated range.
By their numbers in this assay, from the lowest: compounds 3 and 2 (each within the scatter of the next); then compound 1.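

In this assay, cyclohexyl in place of cyclooctyl on an amine nitrogen gives a 1.7-fold lower number from compound 2 to compound 3 (0.24 log units; within the scatter), so this assay does not separate the six-membered ring from the eight-membered ring at this position. Changing the group on the saturated chain carbon bound to a double-bonded chain carbon, with cyclohexylamino in place of 1H-imidazol-1-yl, gives a 4.6-fold lower number from compound 1 to compound 3 (0.67 log units; beyond the scatter), a step that lies beyond the usual scatter and is the only listed step here that does. No supporting measurement is available to explain either step.

The compounds shown leave open whether a smaller ring such as cyclopentyl, or an open chain such as butyl, on the same amine nitrogen would also stay within the scatter of the cyclohexyl compound. They also leave open what happens when the amine nitrogen itself is replaced, for example by an ether oxygen or an amide, while the cyclohexyl group and the rest of compound 3 stay unchanged.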